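The source may hold more compounds than are shown below. What is called first, only, known or untested is meant among the compounds shown, and "the series" means these compounds.

Measured so far in a functional assay on A2780 cells (Homo sapiens) for inhibition, with a stated time of 72 h, tested at 10 uM; a higher number here means more inhibition of growth at the concentration tested, a lower number less inhibition of growth:
compound 1 `CC1(C)CCOc2ccc(NC(=O)Nc3ccc([N+](=O)[O-])cc3)cc21` gives 74%;
compound 2 `CC1(C)CC(C)(C)c2cc(NC(=O)Nc3ccc([N+](=O)[O-])cc3)ccc2O1` gives 79%;
compound 3 `CC1(C)CCOc2ccc(NC(=S)Nc3ccc(OC(F)(F)F)cc3)cc21` gives 16%.

Compound 1 stands second highest of the three numbers. Its value lies within the scatter of that of compound 2, so the two cannot be told apart, while compound 3 lies far lower, beyond the scatter; compound 3, however, differs from compound 1 in more than one place, so its low number cannot be tied to any single change. Compound 4 `CC1(C)CCOc2ccc(NC(=O)Nc3ccc(C(F)(F)F)cc3)cc21` has not yet been measured. It differs from compound 1 in one place: trifluoromethyl in place of nitro on an aromatic carbon. For the measured compounds named here, no measured pair isolates this change, so the expectation rests on compound 1 alone. A moderate drop, somewhat beyond the scatter, is expected: a number 19 percentage points lower from compound 1 to compound 4 (beyond the scatter). For compound 4 the estimated result is 55%, with a range from 20% to 85%.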

Compound 4, percent growth inhibition at one concentration: 47%
Compound 4: the middle estimate sits 8 percentage points above what was measured; low and high end bracket the measured number.
By their numbers in this assay, from the lowest: compound 3; then compound 4; then compounds 1 and 2 (each within the scatter of the next).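

For the compounds shown here, replacing nitro with trifluoromethyl on this aromatic carbon gives a number 27 percentage points lower from compound 1 to compound 4 (beyond the scatter) in this assay, the first change here that can be read in one place. The position therefore responds to the group it carries, yet compound 4 still gives 47% at the concentration tested. No measurement here accounts for this step. Still open, as far as these compounds go, is how an amine or a carboxylic acid on this carbon would compare with nitro. From the compounds shown here alone, it is also open whether the same replacement would have a similar effect on the core of compound 2.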